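The compounds below may be only part of what the source reports. "The series", "measured", "known", "first", "only" and "open" are said of these compounds alone.

Measured in a functional assay on ASPC1 cells (Homo sapiens) for cytotoxicity; on this read-out higher numbers stand for weaker inhibition and lower numbers for stronger inhibition:
- Compound 1 `CS(=O)(=O)c1ccc2nc(NC(=O)CCCCCCC(=O)NO)sc2c1`: 13.5 ug/mL
- Compound 2 `CS(=O)(=O)c1ccc2nc(NC(=O)CCCCC(=O)NO)sc2c1`: > 30 ug/mL
- Compound 3 `CCOc1ccc2nc(NC(=O)CCCCC(=O)NO)sc2c1`: 16.7 ug/mL

The value for compound 2 is a limit of the assay and not a number. That leaves two true numbers, those of compound 1 and compound 3, and they lie within the usual scatter of each other.

Compound 4 `COc1ccc2nc(NC(=O)CCCCCCC(=O)NO)sc2c1` keeps the chain and core of compound 1 and changes one group: methoxy in place of methylsulfonyl on an aromatic carbon.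

The closest measured swap is ethoxy in place of methylsulfonyl, an at least 1.7-fold lower number from compound 2 to compound 3 (0.25 log units; that floor lies within the scatter). It is only a floor, it lies within the scatter, and it was seen on the shorter chain. Shortening the chain gave an at least 2.2-fold higher number from compound 1 to compound 2 (0.34 log units; beyond the scatter), so the chain effect is a separate one, and compound 4 does not undergo it.

Together these point to a modest fall in the number at most, perhaps none beyond the scatter. The expected change is a 1.7-fold lower number from compound 1 to compound 4 (0.23 log units; within the scatter). For compound 4 the estimated value is 8 ug/mL, with an expected range from 3 ug/mL to 20 ug/mL.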

Compound 4, half-maximal inhibitory concentration: 0.79 ug/mL
Compound 4: middle estimate off by 10-fold (1.01 log units), on the high side; the whole stated range lies above it.
By their numbers in this assay, from the lowest: compound 4; then compounds 1 and 3 (each within the scatter of the next). At a limit, above all of these: compound 2.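

On the longer chain in this assay, putting methoxy in place of methylsulfonyl on this aromatic carbon gives a 17-fold lower number from compound 1 to compound 4 (1.23 log units; beyond the scatter), so a change at this one position can move the number a long way, and the methylsulfonyl group is not needed for a low number on this chain. The earlier ethoxy swap could not show this size, since it could be read only as a floor, because compound 2 stands at a limit of the assay and not at a number: the limit of > 30 ug/mL in this assay, at which 1 of the 4 values shown sits.

This single pair gives the size of the change but not its cause, so it remains unclear which feature of the two groups accounts for it. It also leaves open whether an amine or a carboxylic acid on this aromatic carbon, or a longer chain than that of compound 4, would keep the number this low.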